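This account rests on a few compounds, and the source may have more. Where it says the series, first, only, none or still open, it means among the compounds named here.

Working notes on the series. Compound 1 (`NS(=O)(=O)c1ccc(Nc2nc(-c3cccc(-c4ccccc4)c3)c3nc[nH]c3n2)cc1`) reads > 100000 nM in a functional assay on A2058 cells (Homo sapiens) for antiproliferative activity, read by luminescence and CellTiter-Glo, with a stated time of 96 h (a lower number here means a stronger inhibitor, a higher number a weaker inhibitor), and this is a limit, not a number. For the measured compounds named here, compound 2 (`CN1CCC(CNC(=O)c2cccc(-c3ccc(F)c(C(=O)Nc4c[nH]nc4C(=O)Nc4ccc(F)cc4)c3F)c2)CC1`) gives 3340 nM in this assay as the only true number so far, so no measured step is available to size the next change against. Compound 3 (`O=C(Nc1ccc(F)cc1)c1n[nH]cc1NC(=O)c1c(F)ccc(-c2ccccc2)c1F`) follows from compound 2 through one change, (hydrogen in place of ((1-methylpiperidin-4-yl)methyl)carbamoyl on an aromatic carbon), which puts hydrogen in place of ((1-methylpiperidin-4-yl)methyl)carbamoyl on an aromatic carbon. The expectation therefore rests on compound 2 at 3340 nM alone and stays loose. A moderate move towards weaker inhibition in this assay is expected, probably somewhat beyond the scatter, with the estimated step of a 1.8-fold higher number from compound 2 to compound 3 (0.25 log units; within the scatter) as its size. For compound 3 the expected value is 6000 nM within an estimated range of 1500 nM to 30000 nM as the working figure.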

Compound 3, half-maximal inhibitory concentration: 2370 nM
Compound 3: middle estimate off by 2.5-fold (0.40 log units), on the high side; low and high end bracket the measured number.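

In this assay the change reads as a 1.4-fold lower number from compound 2 to compound 3 (0.15 log units; within the scatter) and so shows no measurable difference between the two compounds. For the compounds shown here, this is the first sign of how the position responds: on this aromatic carbon, meta to a large group, the ((1-methylpiperidin-4-yl)methyl)carbamoyl group and hydrogen cannot be told apart in this read-out. Nothing among the values shown bears on why this is so.

Open, from the compounds shown here alone, is whether the position tolerates substitution generally or only these two groups, which a carboxylic acid, a primary amine or a shorter chain ending in a dimethylamino group would help to settle. Also open, going by these compounds, is whether any change elsewhere on the shared core moves the number beyond the scatter, since this single step offers no guide to that.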